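A few compounds are considered here, and "the series" means these few. Any claim that something is new, unique, unknown or untested is made for them only; others in the source may bear on it.

The compounds share a core of compound 1 `Cn1cncc1C(OCc1ccc(C#N)cc1-c1cccc2ccccc12)c1ccc(C#N)nc1`, a naphthalen-1-yl bearer. In an assay on isolated protein (Bos taurus) for inhibition of geranylgeranyl transferase type-1 subunit beta (Homo sapiens) (a lower number here means a stronger inhibitor, a higher number a weaker inhibitor), compound 1 gives > 10 nM, which is a limit of the assay and not a number (the limit of > 10 nM in this assay, at which 1 of the 3 values shown sits). Compound 3 `Cn1cncc1C(OCc1ccc(C#N)cc1-c1cccc(Cl)c1)c1ccc(C#N)nc1`, with 3-chlorophenyl, gives 8620 nM in this assay. The step that the limit leaves unreadable from compound 1 to compound 3 is therefore left unreadable by that limit. Compound 2 `Cn1cncc1C(OCc1ccc(C#N)c(-c2ccc3ccccc3c2)n1)c1ccc(C#N)cc1` gives 2600 nM in this assay, the lowest of the two numbers shown; its nearest neighbour is compound 3, whose number lies higher by a gap beyond the scatter, though no single-place step connects the two.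

Compound 4 `Cn1cncc1C(OCc1ccc(C#N)c(-c2ccc(Cl)c(Cl)c2)n1)c1ccc(C#N)cc1` differs from compound 2 by 3,4-dichlorophenyl in place of naphthalen-2-yl on an aromatic carbon. Going by the values given here, no measured step bears on this exchange: the only single-place step, from a bicyclic aromatic to a chlorinated phenyl, cannot be sized. Compound 4 is therefore expected to sit near compound 2, with a modest shift toward a higher number, the expected step being a 1.7-fold higher number from compound 2 to compound 4 (0.24 log units; within the scatter). For compound 4 the estimate in this assay is 4500 nM, with a range from 1200 nM to 17000 nM.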

Compound 4, half-maximal inhibitory concentration: 1600 nM
The estimate for compound 4 lay 2.8-fold (0.45 log units) above the measured number; low and high end bracket the measured number.
By their numbers in this assay, from the lowest: compounds 4 and 2 (each within the scatter of the next); then compound 3.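

On the aromatic carbon next to the ring nitrogen and ortho to a cyano group, 3,4-dichlorophenyl in place of naphthalen-2-yl gives a 1.6-fold lower number from compound 2 to compound 4 (0.21 log units; within the scatter) in this assay. Going by these compounds alone, this is the first readable step at this position, and it shows that one six-membered aromatic ring of carbon only, bearing two chlorine atoms, leaves the number within the scatter of the two-ring naphthalen-2-yl group. Nothing measured here accounts for this result.

Compound 1 gives > 10 nM, which is a limit of the assay and not a number, so the step from it to compound 3 cannot be read. Going by these compounds, it remains open how this position would respond to an unsubstituted phenyl, or to a non-aromatic group such as a piperidine or a morpholine.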